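Hydrogen in place of sec-butyl on a shared core

A few compounds are considered here, and "the series" means these few. Any claim that something is new, unique, unknown or untested is made for them only; others in the source may bear on it.

Three compounds share one core and differ only in the group on a saturated chain carbon bound to an amide-type nitrogen and a carbonyl carbon. Compound 1 `C[C@@H](O)[C@H](NC(=O)CN(c1nc(Cl)nc2[nH]cnc12)C1CC1)C(=O)O` gives 30.1% in a functional assay on the whole organism (Tail, strain ICR) with Mus musculus as the target, in the tail flick test, with a stated time of 60 min, at a dose of 25 umol/kg by the oral route; a lower number here means a weaker effect, a higher number a stronger effect of the compound at the dose given. Compound 2 `NC(=O)CC[C@H](NC(=O)CN(c1nc(Cl)nc2[nH]cnc12)C1CC1)C(=O)O` gives 38.4% in this assay, and compound 3 `CC[C@H](C)[C@H](NC(=O)CN(c1nc(Cl)nc2[nH]cnc12)C1CC1)C(=O)O` gives 36%. Compound 3 thus holds the second highest of the three numbers, with a number 2.4 percentage points lower from compound 2 to compound 3 (within the scatter) and a number 5.9 percentage points higher from compound 1 to compound 3 (within the scatter), so none of the three is set apart. Compound 4 `O=C(O)CNC(=O)CN(c1nc(Cl)nc2[nH]cnc12)C1CC1` carries hydrogen in place of sec-butyl on a saturated chain carbon bound to an amide-type nitrogen and a carbonyl carbon. Among the measured compounds shown here, the steps that bear on this change, a number 2.4 percentage points lower from compound 2 to compound 3 (within the scatter) and a number 8.3 percentage points higher from compound 1 to compound 2 (within the scatter), both stayed within the scatter, so no step beyond the scatter is expected in this assay. Compound 4 is therefore estimated at 34%, between 22% and 46%. For compound 4 this means an expected step of a number 2 percentage points lower from compound 3 to compound 4 (within the scatter).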

Compound 4, a percentage reported as activity, at one dose (the size of the read-out at that dose, not a potency): 38.9%
Estimate against measurement, compound 4: 4.9 percentage points below; measured number inside the range.
By their numbers in this assay, from the lowest: compounds 1, 3, 2 and 4 (each within the scatter of the next).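

In this assay, replacing the side group with plain hydrogen gives no step beyond the scatter, whichever group leaves: a number 2.9 percentage points higher from compound 3 to compound 4 (within the scatter) for sec-butyl, a number 0.5 percentage points higher from compound 2 to compound 4 (within the scatter) for 2-carbamoylethyl and a number 8.8 percentage points higher from compound 1 to compound 4 (within the scatter) for 1-hydroxyethyl. At this dose, then, compound 4 shows that none of these three groups is needed on this carbon for an effect of this size.

As far as these compounds go, whether an amine, a second carboxylic acid or a longer chain here would move the number remains open. No measurement shown gives a reason why the three groups and hydrogen cannot be told apart.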